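The compounds below may be only part of what the source reports. "The series", "measured", "known", "first", "only" and "open" are said of these compounds alone.

Of the compounds shown here, two have been measured so far in a functional assay on DU-145 cells (Homo sapiens) for inhibition, read by trypan blue exclusion, with a stated time of 96 h; a lower number here means a stronger inhibitor of growth, a higher number a weaker inhibitor of growth. Compound 1, with the structure `Cc1ccc(CS(=O)(=O)/C(=C/c2ccc(S(C)(=O)=O)cc2)C(=O)c2ccc(Br)cc2)cc1`, gives 10000 nM. Compound 2, with the structure `O=C(/C(=C\c1ccc([N+](=O)[O-])c(O)c1)SCc1ccc(Br)cc1)c1cc(Cl)ccc1O`, gives 10000 nM in this assay. On these numbers compound 2 stands level with compound 1, its nearest point of comparison, and the two readings do not differ beyond the usual scatter of the measurement.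

Compound 3, with the structure `O=C(/C(=C\c1ccc([N+](=O)[O-])c(O)c1)SCc1ccc(Br)cc1)C1CCNC1`, has not been measured yet. It differs from compound 2 at one place: pyrrolidin-3-yl in place of 5-chloro-2-hydroxyphenyl on a carbonyl carbon. Among the compounds with values here, no pair of measured compounds that differ in one place is available, so the size of this step cannot be read from the data. Both measured compounds give the same weak reading, and nothing among them points toward a move in either direction, so a step no larger than the scatter is expected. The step of no change at the digits printed from compound 2 to compound 3 (within the scatter) is the estimated step. Compound 3 is therefore expected to give about 10000 nM in this assay, with a plausible range from 3000 nM to 30000 nM.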

Compound 3, concentration for 50% growth inhibition: > 100000 nM
Compound 3: no number, only a limit (the forecaster's own chance of this, stated with the estimate: 50%); at least 10-fold (1.00 log units) between middle value and limit.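

In this assay compound 3 gives > 100000 nM, and this is a limit of the assay, not a number. The earlier compounds shown here offered no step between compounds differing in one place, whereas this pair shows that the group on this carbonyl carbon can change the reading: pyrrolidin-3-yl in place of 5-chloro-2-hydroxyphenyl brings an at least 10-fold higher number from compound 2 to compound 3 (1.00 log units; beyond the scatter), which lies beyond the usual scatter even though compound 2 was already a weak inhibitor of growth. The step therefore has a lower bound but no exact size: the limit of > 100000 nM in this assay, at which 1 of the 3 values shown sits.

The change removes an aromatic ring, its chlorine and its hydroxyl group and brings in a non-aromatic ring with a nitrogen all at once, so the compounds shown cannot tell which of these differences carries the step. From the compounds shown here alone, whether a plain phenyl group, lacking the chlorine and the hydroxyl, or a cyclopentyl group, lacking the ring nitrogen, would read like compound 2 or like compound 3 at this carbonyl carbon remains open.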